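The compounds below may be only part of what the source reports. "The series", "measured", "known", "first", "only" and "open" are said of these compounds alone.

Measured in a functional assay on DU-145 cells (Homo sapiens) for inhibition, read by trypan blue exclusion, with a stated time of 96 h; a higher number here means a weaker inhibitor of growth, a lower number a stronger inhibitor of growth:
compound 1 `Cc1ccc(S(=O)(=O)/C(=C/c2sccc2C)C(=O)c2ccc(Br)cc2)cc1`: 25000 nM
compound 2 `CN(C)c1ccc(/C=C(/SCc2ccc(F)cc2)C(=O)c2ccc(Br)cc2)cc1`: 50000 nM
compound 3 `CN(C)c1ccc(/C=C(/SCc2ccc(F)cc2)C(=O)c2ccc(C(=O)O)cc2)cc1`: 10000 nM

Compound 2 gives 50000 nM, within the scatter of compound 1 and separated from compound 3 by a step beyond the scatter. Compound 4 `Cc1ccc(S(=O)(=O)/C(=C/c2ccc(N(C)C)cc2)C(=O)c2ccc(Br)cc2)cc1` has (4-methylphenyl)sulfonyl in place of (4-fluorobenzyl)sulfanyl on a double-bonded chain carbon bound to a carbonyl carbon and a double-bonded chain carbon. Within the data shown here, the only measured step, a 5.0-fold lower number from compound 2 to compound 3 (0.70 log units; beyond the scatter), lies at another place and gives a modest scale, not a direct precedent. Compound 1 carries the same (4-methylphenyl)sulfonyl and gives 25000 nM, although the rest of it differs from compound 4. No change beyond the scatter is therefore expected in this assay. The expected change is a 1.7-fold lower number from compound 2 to compound 4 (0.22 log units; within the scatter). Compound 4 is estimated at 30000 nM, with an expected range of 10000 nM to 80000 nM.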

Compound 4, concentration for 50% growth inhibition: 50000 nM
For compound 4 the middle estimate is 1.7-fold (0.22 log units) below the measured one; measured number inside the range.
By their numbers in this assay, from the lowest: compound 3; then compounds 1, 2 and 4 (each within the scatter of the next).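

In this assay, (4-methylphenyl)sulfonyl in place of (4-fluorobenzyl)sulfanyl on this double-bonded chain carbon gives no change at the digits printed from compound 2 to compound 4 (within the scatter), so with the bromo group retained, this exchange leaves no readable mark. 4-(dimethylamino)phenyl in place of 3-methylthiophen-2-yl gives a 2.0-fold higher number from compound 1 to compound 4 (0.30 log units; within the scatter), so this second place also shows no step beyond the scatter, unlike carboxy in place of bromo. No measurement here offers an explanation for either result.

From the compounds shown here alone, whether carboxy in place of bromo has the same effect alongside (4-methylphenyl)sulfonyl remains open. Also open, going by these compounds, is how a smaller methylsulfonyl or a primary amine would read at the double-bonded chain carbon.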